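The source may report more compounds than this note shows. Statements on the series, on what has been measured and on what is new or still open speak of the compounds shown alone.

Working notes on the series in an ADME assay on HaCaT cells (Homo sapiens) for inhibition, read by sulforhodamine B assay, with a stated time of 48 h; a higher number here means a weaker inhibitor of growth, a lower number a stronger inhibitor of growth.

Of the compounds shown here, three carry numbers so far. Compound 1, `COc1ccc(/C=C/C2CC(=O)C=CO2)cc1OC`, gives 134 uM. Compound 2, `COc1cc(/C=C/C2CC(=O)C=CO2)cc(OC)c1OC`, gives 155 uM, the highest of the three numbers; its nearest neighbour is compound 1, within the scatter, and its furthest is compound 3, `COc1ccc(C2CC(=O)C(I)=CO2)cc1`, which gives 53.3 uM, a gap beyond the scatter. For the measured compounds named here, the only single-point step measured, a 1.2-fold higher number from compound 1 to compound 2 (0.06 log units; within the scatter), stays within the scatter.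

Compound 4, `COc1cc(/C=C/C2CC=CC(=O)O2)cc(OC)c1OC`, has not been measured. It differs from compound 2 as follows: a group of 7 heavy atoms (5 carbon, 2 oxygen; one six-membered non-aromatic ring with 1 hetero atom) in place of a group of 7 heavy atoms (5 carbon, 2 oxygen; one six-membered non-aromatic ring with 1 hetero atom), on a double-bonded chain carbon bound to a double-bonded chain carbon. The two groups match in what is counted, and the change sits on a double-bonded chain carbon bound to a double-bonded chain carbon.

Going by the values given here, no measured step touches this kind of rearrangement; the one step in hand, from compound 1 to compound 2, concerns a methoxy on an aromatic carbon and gives no guide. With nothing to lean on, no step beyond the scatter is expected in this assay, in either direction: the estimated step is a 1.0-fold lower number from compound 2 to compound 4 (0.01 log units; within the scatter). Compound 4 is therefore expected to give about 150 uM, with a range from 55 uM to 400 uM.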

Compound 4, concentration for growth inhibition (reported as GI): 21.6 uM
Beside the measured number, compound 4's estimate is 6.9-fold (0.84 log units) above it; the measured number lies below the stated range.
By their numbers in this assay, from the lowest: compound 4; then compound 3; then compounds 1 and 2 (each within the scatter of the next).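

In this assay, one six-membered non-aromatic ring with 1 hetero atom replaces another with the same atoms and the same counts, on a double-bonded chain carbon bound to a double-bonded chain carbon, and this gives a 7.2-fold lower number from compound 2 to compound 4 (0.86 log units; beyond the scatter). For the compounds shown here, the number at this position therefore responds to how the ring atoms are joined, even with every counted feature unchanged, whereas the only earlier step, a 1.2-fold higher number from compound 1 to compound 2 (0.06 log units; within the scatter), stayed within the scatter and showed no such response on the aromatic carbon. No available evidence bears on what lies behind this difference.

The compounds shown leave open whether the rearranged ring gives a similar step with the aromatic substitution of compound 1. Also open, as far as these compounds go, is how an amine or a carboxylic acid on the aromatic ring of compound 4 would shift its number.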